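This account rests on a few compounds, and the source may have more. Where it says the series, first, only, none or still open, it means among the compounds named here.

Measured in a functional assay (strain AB) with Danio rerio as the target, read by microscopy, with a stated time of 1 h; a higher number here means that more compound is needed for the effect, a lower number that less compound is needed:
- compound 1 `CCN1CCc2c(sc(NC(=O)Nc3ccc(Cl)cc3)c2C#N)C1`: > 25000 nM (a limit)
- compound 2 `CCN1CCc2c(sc(NC(=O)Nc3ccc(Cl)cc3)c2C(=O)NC)C1`: > 25000 nM (a limit)
- compound 3 `CCN1CCc2c(sc(NC(=O)Nc3ccc(Cl)cc3)c2C(=O)OC)C1`: > 25000 nM (a limit)

Compound 3 therefore has no number to its name: its > 25000 nM is a limit of this assay and nothing more. The same holds across the set, as the limit of > 25000 nM in this assay, at which 3 of the 3 values shown sit, shows for all the measured compounds.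

Compound 4 `CCN1CCc2c(sc(NC(=O)Nc3ccc(Cl)cc3)c2C(=O)c2nc(C)no2)C1` keeps the shared core and the carbonyl carbon of compound 3 but carries 3-methyl-1,2,4-oxadiazol-5-yl in place of methoxy on that carbonyl carbon 3-methyl-1,2,4-oxadiazol-5-yl in place of methoxy on a carbonyl carbon in the change counted here.

Going by the values given here, three measured steps touch this same aromatic carbon and its carbonyl substituent: a step that the two limits leave unreadable from compound 1 to compound 3 for the ester against the nitrile, a step that the two limits leave unreadable from compound 1 to compound 2 for the amide against the nitrile, and a step that the two limits leave unreadable from compound 2 to compound 3 for the ester against the amide. None of them has a readable size, so they offer no size or direction to carry over. Among the compounds with values here, they show only that these three groups all leave the result at the limit.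

The step expected in this assay is therefore none that can be sized, and the estimated step is a number no higher from compound 3 to compound 4 (the limit leaves the size open) as a rough placeholder, with a report at the limit the likeliest outcome. For compound 4 the expected value is 25000 nM in an estimated range from 4000 nM to 50000 nM for now.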

Compound 4, half-maximal effective concentration: > 25000 nM
Compound 4 ended at the assay's limit (the forecaster's own chance of this, stated with the estimate: 65%); the middle value sits exactly at the limit.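

Compound 4, at > 25000 nM in this assay, gives a limit and not a number, so none of its steps from compound 1, compound 2 or compound 3 can be read, and all four compounds share the same result: the limit of > 25000 nM in this assay, at which 4 of the 4 values shown sit.

The compounds shown leave open whether any group at this aromatic carbon changes the half-maximal effective concentration in this assay, and by how much.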